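This account rests on a few compounds, and the source may have more. Where it says the series, first, only, none or still open, it means among the compounds named here.

Measured in a functional assay on HepG2 cells (Homo sapiens) for antiproliferative activity, read by MTT assay, with a stated time of 48 h; on this read-out higher numbers stand for weaker inhibition and lower numbers for stronger inhibition:
- compound 1 `CCn1c(C(=O)NCCCN(C)C)ccc1C(CC)(CC)c1ccc(OCCC(O)(CC)CC)c(C)c1`: 110 nM
- compound 2 `CCN(CC)CCNC(=O)c1ccc(C(CC)(CC)c2ccc(OCCC(O)(CC)CC)c(C)c2)n1CC`: 230 nM
- compound 3 `C#CC(C)OC(=O)c1ccc(C(CC)(CC)c2ccc(OCCC(O)(CC)CC)c(C)c2)n1CC`: > 50000 nM (a limit, not a number)

Compound 3 gives only a limit: the limit of > 50000 nM in this assay, at which 1 of the 3 values shown sits. Compound 4 `C#CCCOC(=O)c1ccc(C(CC)(CC)c2ccc(OCCC(O)(CC)CC)c(C)c2)n1CC` has the same atoms, joined differently: but-3-yn-1-yl in place of 1-methylprop-2-yn-1-yl on an oxygen next to a carbonyl group. The nearest evidence is an at least 450-fold higher number from compound 1 to compound 3 (2.65 log units; beyond the scatter) and an at least 210-fold higher number from compound 2 to compound 3 (2.33 log units; beyond the scatter), both large and both made on the carbonyl carbon. The modest 2.1-fold higher number from compound 1 to compound 2 (0.32 log units; beyond the scatter) lies further out on the amide chain. Within the data shown here, no measured step exchanges one alkynyl group for another, but compound 4 keeps the oxygen on the carbonyl. No step beyond the scatter is therefore expected in this assay. The expected change is an at least 1.1-fold lower number from compound 3 to compound 4 (0.04 log units; that floor lies within the scatter). The estimate for compound 4 is 45000 nM, with an expected range of 12000 nM to 100000 nM.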

Compound 4, half-maximal inhibitory concentration: > 50000 nM
Compound 4 ended at the assay's limit (the forecaster's own chance of this, stated with the estimate: 70%); middle value at least 1.1-fold (0.04 log units) away from the limit.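

In this assay, compound 4 also gives only a limit, so but-3-yn-1-yl on the oxygen next to a carbonyl group does no more to restore activity than 1-methylprop-2-yn-1-yl: the limit of > 50000 nM in this assay, at which 2 of the 4 values shown sit.

The step between compound 3 and compound 4 cannot be read, as both values are limits. The large gap to the amides holds for this second alkynyl group too, with an at least 450-fold higher number from compound 1 to compound 4 (2.65 log units; beyond the scatter) and an at least 210-fold higher number from compound 2 to compound 4 (2.33 log units; beyond the scatter).

Going by these compounds, how far either alkynyl compound lies past the limit remains open. So does whether the loss follows the oxygen or the missing amine, which a carboxylic acid or a dimethylamino-bearing ester on the same carbonyl would help separate.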